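Changing the oxygen substituent of compound 3

The source may report more compounds than this note shows. Statements on the series, on what has been measured and on what is new or still open speak of the compounds shown alone.

In a functional assay on MCF7 cells (Homo sapiens) for inhibition (on this read-out lower numbers stand for stronger inhibition and higher numbers for weaker inhibition), compound 1 `CC/C=C/C=C/[C@@]1(C)SC(O)=CC1=O` gives 16.9 ug/mL, compound 2 `CCCCCC[C@@]1(C)SC(=O)C=C1OCC(=O)OCC` gives 14.2 ug/mL and compound 3 `CCCCCCCC[C@@]1(C)SC(=O)C=C1OCC(=O)OCC` gives 10.8 ug/mL, so compound 3 stands within the scatter of both others. Compound 4 `CCCCCCCC[C@@]1(C)SC(=O)C=C1OC(=O)OC` differs from compound 3 in one place: methoxycarbonyl in place of (ethoxycarbonyl)methyl on an oxygen on an unsaturated carbon. In words, methoxycarbonyl stands in place of (ethoxycarbonyl)methyl on an oxygen on an unsaturated carbon. Among the compounds with values here, the only measured step, a 1.3-fold lower number from compound 2 to compound 3 (0.12 log units; within the scatter), lengthens the saturated chain and leaves this oxygen substituent untouched, so it offers weak guidance. Within the data shown here, no measured step covers this change, and no shift beyond the scatter is expected in this assay. The estimated change is a 1.0-fold higher number from compound 3 to compound 4 (0.01 log units; within the scatter). For compound 4, the estimated value is 11 ug/mL, with an expected range of 5 ug/mL to 25 ug/mL.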

Compound 4, half-maximal inhibitory concentration: 10.7 ug/mL
For compound 4 the middle estimate is 1.0-fold (0.01 log units) above the measured one; the range from low to high includes it.
By their numbers in this assay, from the lowest: compounds 4, 3, 2 and 1 (each within the scatter of the next).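

In this assay, placing methoxycarbonyl instead of (ethoxycarbonyl)methyl on this oxygen gives a 1.0-fold lower number from compound 3 to compound 4 (0.00 log units; within the scatter) for the change. The read-out therefore does not separate these two groups, although the entering group has 4 heavy atoms and the leaving group 6, and the new group joins the oxygen through its carbonyl. Nothing measured here bears on why the two groups read alike. The compounds shown leave open whether an amine or a carboxylic acid in this substituent would shift the number beyond the scatter. They also leave open whether the same swap on compound 2 would read alike.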